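This account rests on a few compounds, and the source may have more. Where it says the series, first, only, none or still open, it means among the compounds named here.

Compound 1 `COc1ccc(O)c(/C=N/NC(=O)c2ccc(-c3nc4ccccc4s3)cc2)c1` and compound 2 `COc1ccc(/C=N/NC(=O)c2ccc(-c3nc4ccccc4s3)cc2)c(O)c1` share a core in which a hydrazone carbon carries a substituted phenyl ring. Within the data shown here, in an assay on isolated protein for inhibition of Maltase-glucoamylase (Homo sapiens), with a stated time of 15 min (on this read-out lower numbers stand for stronger inhibition and higher numbers for weaker inhibition), compound 1 gives 6500 nM and compound 2 gives 6970 nM; the only measured step, a 1.1-fold higher number from compound 1 to compound 2 (0.03 log units; within the scatter), is small. Compound 3 `COc1ccc(/C=N/NC(=O)c2ccc(-c3nc4ccccc4s3)cc2)cc1OC` carries a 3,4-dimethoxyphenyl at that carbon and in this assay compound 3 is reported as "not active" (no number reported), so no number marks where it stands. Compound 4 `O=C(N/N=C/c1ccc(F)c(Br)c1)c1ccc(-c2nc3ccccc3s2)cc1` differs from compound 3 by 3-bromo-4-fluorophenyl in place of 3,4-dimethoxyphenyl on a carbon with a double bond to nitrogen. Among the measured compounds shown here, no measured step resembles this change, and the one step known, between two hydroxy-methoxy patterns, lies within the scatter, so it offers no direction. Compound 4 is therefore expected to give 8000 nM in this assay, with a range from 2500 nM to 30000 nM.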

Compound 4, half-maximal inhibitory concentration: 28000 nM
Estimate against measurement, compound 4: 3.5-fold (0.54 log units) below; the range from low to high includes it.
By their numbers in this assay, from the lowest: compounds 1 and 2 (each within the scatter of the next); then compound 4.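

In this assay, 3-bromo-4-fluorophenyl on this carbon gives a measurable number, unlike the 3,4-dimethoxyphenyl of compound 3, but it is weaker than either hydroxy-methoxy pattern, with a 4.0-fold higher number from compound 2 to compound 4 (0.60 log units; beyond the scatter) and a 4.3-fold higher number from compound 1 to compound 4 (0.63 log units; beyond the scatter), both beyond the scatter. So this position can hold a ring carrying two halogens and no hydroxy group, at some cost in inhibition. Nothing available explains these differences. Because the ring substituents all change together, the compounds shown leave open which one matters. From the compounds shown here alone, how an amine or a carboxylic acid on this ring would fare also remains open.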